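Methylsulfanyl Added to Compound 2: An Expected Outcome

The source may report more compounds than this note shows. Statements on the series, on what has been measured and on what is new or still open speak of the compounds shown alone.

Measured compounds:
compound 1 `OCC#Cc1ccccc1C#Cc1ccccc1`, 14900 nM
compound 2 `OCCCCC#Cc1ccccc1C#Cc1ccccc1`, 5220 nM

In a functional assay on DU-145 cells (Homo sapiens) for cytotoxicity (a lower number here means a stronger inhibitor of growth, a higher number a weaker inhibitor of growth), compound 1 gives 14900 nM and compound 2 gives 5220 nM. Within the data shown here, compound 2 thus holds the lowest of the two numbers, and the only measured step, a 2.9-fold lower number from compound 1 to compound 2 (0.46 log units; beyond the scatter), separates it from compound 1; that step concerns the saturated chain alone.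

Compound 3 `CSc1ccccc1C#Cc1ccccc1C#CCCCCO` has not yet been measured in this assay. It differs from compound 2 by methylsulfanyl in place of hydrogen on an aromatic carbon. Among the measured compounds shown here, no measured step touches an aromatic carbon of either ring, so the one step known offers no guide to this change; the data give no precedent for it either way. The expectation is therefore a step of a 1.2-fold lower number from compound 2 to compound 3 (0.06 log units; within the scatter), not beyond the scatter. Compound 3 is estimated at 4500 nM, with a range from 1500 nM to 13000 nM.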

Compound 3, concentration for 50% growth inhibition: 4700 nM
Beside the measured number, compound 3's estimate is 1.0-fold (0.02 log units) below it, and the stated range covers the measured number.
By their numbers in this assay, from the lowest: compounds 3 and 2 (each within the scatter of the next); then compound 1.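

In this assay, the first change shown on an aromatic carbon gives a 1.1-fold lower number from compound 2 to compound 3 (0.05 log units; within the scatter) and so stands apart from the earlier step on the saturated chain, which lay beyond the scatter. At this position, on a six-membered aromatic ring of carbon only and ortho to a large group, methylsulfanyl in place of hydrogen therefore leaves compound 3 and compound 2 indistinguishable in this measurement. Nothing available explains this result.

The compounds shown leave open whether an amine or a carboxylic acid at the same position, or a longer chain on the sulfur, would move the number beyond the scatter. They also leave open whether methylsulfanyl would behave the same way on compound 1, with its shorter chain, or on other aromatic carbons.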